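The source may report more compounds than this note shows. Statements on the series, on what has been measured and on what is new or still open speak of the compounds shown alone.

Measured compounds:
Compound 1, `CCCCCCCCCCOc1cc(OCCCCCCCCCC)cc(OCCCCCC(=O)N(c2ccc(C(=O)O)cc2)c2cccc(C(=O)O)c2)c1` — in an assay on isolated protein for binding affinity to P-selectin (Homo sapiens), read by ELISA, tested at 500 uM (a higher number here means more inhibition at the concentration tested (going by the name of the read-out), a lower number less inhibition), compound 1 gives 58%.
Compound 2, `CCCCCCCCCCOc1cccc(OCCCCCC(=O)N(Cc2ccc(C(=O)O)cc2)c2cccc(C(=O)O)c2)c1` — in this assay compound 2 gives 103%.

Going by the values given here, of the two numbers known, compound 1 holds the lower one; compound 2 sits well above it, by a gap that lies beyond the usual scatter. The two structures differ in more than one place, so what separates them cannot be pinned to a single change.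

Compound 3, `CCCCCCCCCCOc1cc(OCCCCCCCCCC)cc(OCCCCCC(=O)N(c2cccc(C(=O)O)c2)c2ccc(C(=O)O)c(C(=O)O)c2)c1`, has not yet been measured. It departs from compound 1 in one place: carboxy in place of hydrogen on an aromatic carbon. Cut one bond further out, the 4-carboxyphenyl of compound 1 reads as 3,4-dicarboxyphenyl in compound 3. Among the compounds with values here, no measured pair shows this change, so its size is open. A small rise is expected, roughly a number 7 percentage points higher from compound 1 to compound 3 (within the scatter), though a step of either direction within the scatter is also plausible. Compound 3 is therefore estimated at 65%, between 35% and 95%.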

Compound 3, a percentage reported as inhibition, at one concentration (the size of the read-out at that concentration, not a potency): 102%
The estimate for compound 3 lay 37 percentage points below the measured number; the whole stated range lies below it.
By their numbers in this assay, from the lowest: compound 1; then compounds 3 and 2 (each within the scatter of the next).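

In this assay, putting carboxy in place of hydrogen on an aromatic carbon, which turns 4-carboxyphenyl into 3,4-dicarboxyphenyl, gives a number 44 percentage points higher from compound 1 to compound 3 (beyond the scatter) and is a large step. Going by these compounds alone, this is the first change in a single place with a measured size here, and it shows that this position, ortho to a carboxy group, responds strongly to the change. No measurement shown accounts for the size of the step, so its origin stays unexplained.

The compounds shown include no hydroxy group, methyl ester or amine at this position, so it remains open whether the carboxylic acid itself is needed for the rise. On these data alone, it is also open whether the same change would bring a similar step on the core of compound 2.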